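The source may report more compounds than this note shows. Statements on the series, on what has been measured and on what is new or still open speak of the compounds shown alone.

Compound 1, `COc1cc(C#N)ccc1OCc1nnc(-c2ccccc2)o1`, was tested in an ADME assay on MCF-10A cells (Homo sapiens) for cytotoxicity, read by MTT assay, with a stated time of 48 h; on this read-out higher numbers stand for weaker inhibition and lower numbers for stronger inhibition. In this assay compound 1 gives > 100000 nM, which is a limit of the assay rather than a number. Compound 2, `COc1ccc(-c2nnc(COc3ccc(C#N)cc3OC)o2)cc1`, carries methoxy in place of hydrogen on an aromatic carbon. In this assay compound 2 gives > 100000 nM, also a limit. The step that the two limits leave unreadable from compound 1 to compound 2 therefore cannot be sized, since both values sit at the limit of > 100000 nM in this assay, at which 3 of the 3 values shown sit. Compound 3, `c1ccc(-c2nnc(COc3ccc(-c4nnco4)cc3)o2)cc1`, has a core whose difference from compound 1 is not broken down here. In this assay compound 3 gives > 100000 nM, again a limit. Compound 4, `COc1ccc(-c2nnc(COc3ccc(-c4nnco4)cc3)o2)cc1`, differs from compound 3 by methoxy in place of hydrogen on an aromatic carbon, the same change as between compound 1 and compound 2. Compound 4 is expected to show a step that the limit leaves unreadable from compound 3 to compound 4, resting on the unreadable step that the two limits leave unreadable from compound 1 to compound 2 and on (the limit of > 100000 nM in this assay, at which 3 of the 3 values shown sit). Compound 4 is thus estimated at 150000 nM, most likely reported only as a limit.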

Compound 4, half-maximal inhibitory concentration: > 100000 nM
Compound 4: a limit, no number (the forecaster's own chance of this, stated with the estimate: 85%); the middle value is on the limit's open side.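

No step can be read from compound 3 to compound 4, as both values are limits and not numbers: the limit of > 100000 nM in this assay, at which 4 of the 4 values shown sit. The compounds shown leave open whether the change from phenyl to 4-methoxyphenyl shifts the value at all, as none of them gives a number.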